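A few compounds are considered here, and "the series" means these few. Any claim that something is new, unique, unknown or untested is made for them only; others in the source may bear on it.

Measured so far in an ADME assay on L6 cells (Rattus norvegicus) for cytotoxicity, read by resazurin assay, with a stated time of 72 h; a lower number here means a stronger inhibitor, a higher number a weaker inhibitor:
- Compound 1 `O=C1[C@H]2N=NN(Cc3nc(-c4ccc(Cl)cc4)no3)[C@H]2C(=O)N1c1ccccc1`: 49.5 ug/mL
- Compound 2 `Cc1ccc(-c2noc(CN3N=N[C@@H]4C(=O)N(c5ccccc5)C(=O)[C@@H]43)n2)cc1`: 15.2 ug/mL

Of these two numbers, the lower belongs to compound 2, at 15.2 ug/mL, so it is the stronger inhibitor of the pair. The next structure, compound 3 `O=C1[C@H]2N=NN(Cc3nc(-c4ccc(C(F)(F)F)cc4)no3)[C@H]2C(=O)N1c1ccccc1`, has trifluoromethyl in place of methyl on an aromatic carbon, turning 4-methylphenyl into 4-(trifluoromethyl)phenyl: trifluoromethyl in place of methyl on an aromatic carbon. Going by the values given here, only one measured step bears on this change, and it is modest: a 3.3-fold lower number from compound 1 to compound 2 (0.51 log units; beyond the scatter). That step also involves the methyl group at this place, and the methyl compound has the lower number. Losing the methyl is therefore expected to move the number back up by a similar amount in this assay, though a single step is thin evidence. The expected change is a 2.6-fold higher number from compound 2 to compound 3 (0.42 log units; beyond the scatter). For compound 3 the estimated value is 40 ug/mL, with an expected range from 15 ug/mL to 100 ug/mL.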

Compound 3, half-maximal inhibitory concentration: 44.4 ug/mL
The estimate for compound 3 lay 1.1-fold (0.05 log units) below the measured number, and the stated range covers the measured number.
By their numbers in this assay, from the lowest: compound 2; then compounds 3 and 1 (each within the scatter of the next).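

In this assay, putting trifluoromethyl in place of methyl on this aromatic ring gives a clear change (a 2.9-fold higher number from compound 2 to compound 3 (0.47 log units; beyond the scatter)), so methyl now stands apart from two different groups at this place rather than from chloro alone. Trifluoromethyl and chloro, by contrast, cannot be told apart here (a 1.1-fold lower number from compound 1 to compound 3 (0.05 log units; within the scatter)), which means that among these three compounds only the methyl compound differs beyond the scatter. No measurement is available that explains why methyl differs from the other two groups.

Still open, going by these compounds, is whether the lower number belongs to methyl in particular or would also appear with a longer chain such as ethyl, or with a methoxy group. An amine or a carboxylic acid at this place could also shift the number in either direction, and these three compounds cannot predict it.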